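The compounds below may be only part of what the source reports. "The series", "measured", "known", "first", "only" and "open" are said of these compounds alone.

Measured so far in a functional assay on MCF7 cells (Homo sapiens) for inhibition, read by MTT assay, with a stated time of 72 h, tested at 10 uM; a lower number here means less inhibition, a higher number more inhibition at the concentration tested (going by the name of the read-out):
compound 1, `CCOC(=O)C1=C(Nc2ccccc2)S/C(=C\c2ccc(OC)cc2)C1=O` — compound 1 gives 14.7%
compound 2, `CCOC(=O)C1=C(Nc2ccccc2)S/C(=C\c2cc(OC)c(O)c(OC)c2)C1=O` — compound 2 gives 12.9%
compound 3, `CCOC(=O)C1=C(Nc2ccc(F)cc2)S/C(=C\c2ccc[nH]2)C1=O` — compound 3 gives < 10%, which is a limit of the assay and not a number

Compound 1 stands at the higher of the two numbers that were actually read, but its gap to compound 2 lies within the usual scatter of this assay, so the two cannot be told apart. Among the compounds with values here, the value of compound 3 is the limit of < 10% in this assay, at which 1 of the 3 values shown sits, and it says only that compound 3 sits at that limit. All three compounds therefore show little inhibition under this assay.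

Compound 4, `CCOC(=O)C1=C(Nc2ccccc2)S/C(=C\c2cc3ncccc3[nH]2)C1=O`, is not yet measured. It differs from compound 1 in one place: a group of 9 heavy atoms (7 carbon, 2 nitrogen; one five-membered aromatic ring with 1 hetero atom, one six-membered aromatic ring with 1 hetero atom) in place of a group of 8 heavy atoms (7 carbon, 1 oxygen; one six-membered aromatic ring of carbon only), on a double-bonded chain carbon bound to a double-bonded ring carbon. Within the data shown here, no step between measured compounds can be used as a guide for this change, so the expectation rests on the low level at which compound 1, compound 2 and compound 3 all sit. The step from compound 1 to compound 4 is expected to be a number 1.7 percentage points lower from compound 1 to compound 4 (within the scatter), that is, none beyond the scatter. Compound 4 is therefore estimated to give 13% in this assay, somewhere between 5% and 25%.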

Compound 4, a percentage reported as inhibition, at one concentration (the size of the read-out at that concentration, not a potency): 42.2%
The estimate for compound 4 lay 29.2 percentage points below the measured number, outside the stated range (above it).
By their numbers in this assay, from the lowest: compounds 2 and 1 (each within the scatter of the next); then compound 4. At a limit, below all of these: compound 3.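

The group on a double-bonded chain carbon bound to a double-bonded ring carbon proves to be a place where the read-out of this assay can move. With the rest of compound 1 unchanged, the 4-methoxyphenyl group gives way to a group holding a five-membered and a six-membered aromatic ring, each with 1 hetero atom, and this brings a number 27.5 percentage points higher from compound 1 to compound 4 (beyond the scatter), the first sign among the compounds shown that this position can lift inhibition clear of the low level seen so far. The entering group also carries 1 hydrogen-bond donor where the leaving group has none, yet this single step cannot separate that feature from the change of rings, and nothing measured here ties the rise to any one feature of the group.

The compounds shown leave open whether a plain phenyl at this place, or an aromatic ring carrying an amine or a carboxylic acid, would keep or lose this level of inhibition. As far as these compounds go, the read-out also stands at one concentration only, so the potency of compound 4 remains open.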